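The source may hold more compounds than are shown below. What is called first, only, known or untested is meant among the compounds shown, and "the series" means these compounds.

Compound 1 `CC1=C(/C=C/C(=O)/C=C/c2cccc(C(F)(F)F)c2)C(C)(C)CCC1O` was measured in a functional assay on CWR22R cells (Homo sapiens) for cytotoxicity, read by MTT assay, with a stated time of 72 h (on this read-out higher numbers stand for weaker inhibition and lower numbers for stronger inhibition), where compound 1 gives 1700 nM. Compound 2 `CC1=C(/C=C/C(=O)/C=C/c2ccc(F)c(C(F)(F)F)c2)C(C)(C)CCC1O` gives 3200 nM in this assay, and the step of a 1.9-fold higher number from compound 1 to compound 2 (0.27 log units; within the scatter) is small enough that the two numbers cannot be told apart. For compound 3 `CC1=C(/C=C/C(=O)/C=C/c2cccc(C(F)(F)F)c2F)C(C)(C)CCC1O` the entry in this assay reads "not determined" (no result reported), so no number is available for it. Compound 4 `CC1=C(/C=C/C(=O)/C=C/c2cc(C(F)(F)F)ccc2F)C(C)(C)CCC1O` differs from compound 1 by fluoro in place of hydrogen on an aromatic carbon. Among the compounds with values here, only one measured step bears on this change: the move from compound 1 to compound 2 is also a fluoro in place of hydrogen on an aromatic carbon, and that step stayed within the scatter. Compound 4 is therefore expected to show a step of a 1.4-fold higher number from compound 1 to compound 4 (0.15 log units; within the scatter) that stays within the scatter, with an estimated 2400 nM and a range from 1000 nM to 6000 nM.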

Compound 4, half-maximal inhibitory concentration: 2000 nM
The estimate for compound 4 lay 1.2-fold (0.08 log units) above the measured number; the measured number falls inside the stated range.
By their numbers in this assay, from the lowest: compounds 1, 4 and 2 (each within the scatter of the next).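

The same swap now holds at a second place on the ring: with fluoro on the aromatic carbon ortho to a large group and para to a trifluoromethyl group, this assay shows a 1.2-fold higher number from compound 1 to compound 4 (0.07 log units; within the scatter). Like the step to compound 2, this change stays within the scatter, so here too fluoro cannot be told apart from hydrogen. No measured property is available to explain this result.

Going by these compounds, whether a larger group at this carbon, such as an amine or a methoxy group, would move the number beyond the scatter stays open. On these data alone, the effect of fluoro as placed in compound 3 also stays open, since that compound has no number.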